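The source may report more compounds than this note shows. Statements on the series, on what has been measured and on what is new or still open speak of the compounds shown alone.

Working notes on the series.

Compound 1 `Cc1cc(OCCCCCCC[N+]2(C)CCCCC2)cc(-n2cc(C(=O)Nc3cc(F)cc(F)c3)c(=O)c3ccc(N(C)C)nc32)c1` and compound 2 `Cc1cc(OCCCCCCC[N+]2(C)CCN(C)CC2)cc(-n2cc(C(=O)Nc3cc(F)cc(F)c3)c(=O)c3ccc(N(C)C)nc32)c1` share one core and differ only in the charged head at the end of the chain. In an assay on LX2 cells for inhibition of COL1A1 promoter (Homo sapiens), read by a luciferase reporter, with a stated time of 24 h, tested at 50 uM (a lower number here means a weaker effect, a higher number a stronger effect of the compound at the concentration tested), compound 1 gives 79.7%, while compound 2 gives 38.2%. Going by the values given here, the one step measured so far, a number 41.5 percentage points lower from compound 1 to compound 2 (beyond the scatter), is the only comparison available, and on it compound 2 stands lowest of the two numbers, with compound 1 the nearest neighbour at a value well beyond the scatter above it.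

Compound 3 `Cc1cc(OCCCCCCC[N+](C)(C)C2CCCCC2)cc(-n2cc(C(=O)Nc3cc(F)cc(F)c3)c(=O)c3ccc(N(C)C)nc32)c1` is the next member. Relative to compound 2 the change is a group of 9 heavy atoms (8 carbon, 1 nitrogen; one six-membered non-aromatic ring of carbon only) in place of a group of 8 heavy atoms (6 carbon, 2 nitrogen; one six-membered non-aromatic ring with 2 hetero atoms), on a saturated chain carbon, seven bonds along the chain from an oxygen on an aromatic ring. This change runs the measured step backwards in one respect: the six-membered non-aromatic ring with 2 hetero atoms that entered from compound 1 to compound 2 leaves again, and a six-membered non-aromatic ring of carbon only enters, now joined to the charged nitrogen rather than containing it. Because the loss of the carbon-only ring coincided with a number 41.5 percentage points lower from compound 1 to compound 2 (beyond the scatter), its return is expected to recover much of that drop, giving an expected step of a number 31.8 percentage points higher from compound 2 to compound 3 (beyond the scatter). Compound 3 is therefore estimated at 70% in this assay, within a range from 45% to 88%.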

Compound 3, a percentage reported as inhibition, at one concentration (the size of the read-out at that concentration, not a potency): 89.1%
Estimate against measurement, compound 3: 19.1 percentage points below, and the stated range ends below it.
By their numbers in this assay, from the lowest: compound 2; then compounds 1 and 3 (each within the scatter of the next).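

In this assay, a group with a six-membered non-aromatic ring of carbon only in place of the group with a six-membered non-aromatic ring with 2 hetero atoms gives a number 50.9 percentage points higher from compound 2 to compound 3 (beyond the scatter), so the low number at this position now stands against two different heads rather than one. The comparison of the two heads without the second nitrogen gives a number 9.4 percentage points higher from compound 1 to compound 3 (within the scatter): a charged nitrogen inside a six-membered ring and one carrying a carbon-only ring as a substituent cannot be told apart here, so this change in the head's shape leaves no separable mark on the read-out. No measurement offered here bears on why the head with 2 hetero atoms in its ring stands apart from the other two.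

A morpholine ring on the charged nitrogen, with an oxygen in place of the second ring nitrogen, would show whether any second ring hetero atom goes with the low number or only that nitrogen does. As far as these compounds go, a plain trimethylammonium head without a ring, and a shorter or longer chain, also remain open, and all three numbers describe one concentration, not potency.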